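A few compounds are considered here, and "the series" means these few. Any claim that something is new, unique, unknown or untested is made for them only; others in the source may bear on it.

Measured so far:
- Compound 1, `COCN(c1ccc2c(c1)S(=O)(=O)N=C(c1c(O)c(-c3cccs3)nn(CCC(C)C)c1=O)N2)S(C)(=O)=O`: > 1000 nM
- Compound 2, `CCC(C)(C)Cn1nc(-c2cccs2)c(O)c(C2=NS(=O)(=O)c3cc(NS(C)(=O)=O)ccc3N2)c1=O`: > 1000 nM

Both compounds were tested in an ADME assay on Huh-7 cells (Homo sapiens) for cytotoxicity, with a stated time of 72 h; on this read-out lower numbers stand for higher toxicity in this test and higher numbers for lower toxicity in this test. For compound 1 the result of > 1000 nM is a limit of the assay, not a number. For compound 2 the result of > 1000 nM is likewise a limit, not a number. So compound 2 stands at the limit of > 1000 nM in this assay, at which 2 of the 2 values shown sit, and no ordering between the two compounds can be drawn from this.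

Compound 3, `CS(=O)(=O)Nc1ccc2c(c1)S(=O)(=O)N=C(c1c(O)c(-c3cccs3)nn(Cc3ccc(F)cc3)c1=O)N2`, has not yet been measured. It differs from compound 2 in one place: 4-fluorophenyl in place of 1,1-dimethylpropyl on a saturated chain carbon bound to an aromatic nitrogen. Among the measured compounds shown here, no step between measured compounds is available to show what such a change does to the read-out.

Given that the only two values shown both sit at the limit of > 1000 nM in this assay, at which 2 of the 2 values shown sit, the expectation for the step that the limit leaves unreadable from compound 2 to compound 3 is none beyond the scatter. Compound 3 is therefore estimated at 2000 nM, with a range from 1000 nM to 5000 nM, and it is quite likely that the assay again reports only a limit for compound 3.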

Compound 3, half-maximal cytotoxic concentration: > 1000 nM
Compound 3 gave a limit, no number (the forecaster's own chance of this, stated with the estimate: 80%); the middle value does not contradict the limit.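

In this assay compound 3 gives > 1000 nM as a limit, not a number. Compound 2 also sits at a limit, so no step can be read from compound 2 to compound 3. The compounds shown leave open at what concentration any of them becomes toxic to these cells, and whether swapping these groups changes it: the limit of > 1000 nM in this assay, at which 3 of the 3 values shown sit.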